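The source may report more compounds than this note shows. Statements on the series, on what has been measured and on what is new or still open speak of the compounds shown alone.

Measured compounds:
- Compound 1 `CN1C[C@H](C(=O)Nc2ccc(F)cc2)[C@@H](c2ccc(/C=C/C(=O)Nc3ccccc3N)cc2)C1`: 34 mL/min/kg
- Compound 2 `COc1ccc(NC(=O)[C@H]2CN(C)C[C@@H]2c2ccc(/C=C/C(=O)Nc3ccccc3N)cc2)cc1`: 54 mL/min/kg
- Compound 3 `CN1C[C@H](C(=O)Nc2ccc(C3CC3)cc2)[C@@H](c2ccc(/C=C/C(=O)Nc3ccccc3N)cc2)C1`: 60 mL/min/kg

These three compounds share one core and differ only in a single group on an aromatic carbon. In an in vitro ADME assay on microsomes from liver (Mus musculus) for pharmacokinetics, read by LC-MS, with a stated time of 10 min, tested at 1 uM (a lower number here means slower removal, a higher number faster removal of the compound), compound 3 gives 60 mL/min/kg. This number cannot be told apart from the other two, as the steps show: a 1.8-fold higher number from compound 1 to compound 3 (0.25 log units; within the scatter) and a 1.1-fold higher number from compound 2 to compound 3 (0.05 log units; within the scatter).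

The next compound is compound 4 `CN1C[C@H](C(=O)Nc2ccc(Br)cc2)[C@@H](c2ccc(/C=C/C(=O)Nc3ccccc3N)cc2)C1`, which has not yet been measured. Among the compounds with values here, it keeps the core of compound 3 and changes only that one group: bromo in place of cyclopropyl on an aromatic carbon. The new group sits in the same place, on an aromatic carbon of a six-membered aromatic ring, para to a large group.

Within the data shown here, no measured step involves bromo, so the evidence is indirect. The three exchanges made at this place are all small: a 1.6-fold higher number from compound 1 to compound 2 (0.20 log units; within the scatter), a 1.8-fold higher number from compound 1 to compound 3 (0.25 log units; within the scatter) and a 1.1-fold higher number from compound 2 to compound 3 (0.05 log units; within the scatter). None of them goes beyond the scatter, so no step beyond the scatter is expected here either, and no direction can be claimed with any confidence.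

The expected step is a 1.3-fold lower number from compound 3 to compound 4 (0.10 log units; within the scatter).

For compound 4, the estimated clearance is 48 mL/min/kg, with an expected range of 27 mL/min/kg to 85 mL/min/kg.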

Compound 4, clearance: 16 mL/min/kg
Estimate against measurement, compound 4: 3.0-fold (0.48 log units) above, and the stated range ends above it.
By their numbers in this assay, from the lowest: compound 4; then compounds 1, 2 and 3 (each within the scatter of the next).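

In this assay, this position now shows that the group it carries can change the number, as bromo gives a 3.8-fold lower number from compound 3 to compound 4 (0.57 log units; beyond the scatter) and a 3.4-fold lower number from compound 2 to compound 4 (0.53 log units; beyond the scatter) and a 2.1-fold lower number from compound 1 to compound 4 (0.33 log units; beyond the scatter) and all three steps are modest but beyond the scatter. Fluoro, methoxy and cyclopropyl could not be told apart from one another, so the flat picture they gave holds only for those three groups, and compound 4 alone stands clear of all the others, with the slowest removal of the four. The smallest of the three steps is the one from fluoro, yet compound 1 itself cannot be separated from compound 2 or compound 3, so no simple ranking of groups follows, and nothing available here explains why bromo stands apart.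

From the compounds shown here alone, whether chloro or iodo would fall with bromo or with the other three remains open, and so does how an amine or a carboxylic acid would behave at this place. Going by these compounds, it is also open whether bromo in place of cyclopropyl would give a similar step on a different core.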